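The source may hold more compounds than are shown below. What is called first, only, known or untested is meant among the compounds shown, and "the series" means these compounds.

Compound 1 `O=[N+]([O-])c1ccc(CN2CCC(n3cc(CC(OCc4cc(-c5cccc(F)c5)no4)c4ccc(Br)cc4)nn3)CC2)cc1` and compound 3 `O=[N+]([O-])c1ccc(CN2CCC(n3cc(CC(OCc4cc(-c5ccccc5F)no4)c4ccc(Br)cc4)nn3)CC2)cc1` are two cores of the series; they differ by 2-fluorophenyl in place of 3-fluorophenyl on an aromatic carbon. In a functional assay on PC-3 cells (Homo sapiens) for cytotoxicity, with a stated time of 48 h (on this read-out higher numbers stand for weaker inhibition and lower numbers for stronger inhibition), compound 1 gives 9000 nM, and compound 3 gives 6000 nM, a 1.5-fold lower number from compound 1 to compound 3 (0.18 log units; within the scatter). Compound 2 `COc1cccc(-c2cc(COC(Cc3cn(C4CCN(Cc5ccc([N+](=O)[O-])cc5)CC4)nn3)c3ccc(Br)cc3)on2)c1` carries, on the core of compound 1, the change (methoxy in place of fluoro on an aromatic carbon). In this assay compound 2 reaches only a limit, > 25000 nM, namely (the limit of > 25000 nM in this assay, at which 1 of the 3 values shown sits). That change gave an at least 2.7-fold higher number from compound 1 to compound 2 (0.44 log units; beyond the scatter). Compound 4 `COc1ccccc1-c1cc(COC(Cc2cn(C3CCN(Cc4ccc([N+](=O)[O-])cc4)CC3)nn2)c2ccc(Br)cc2)on1` carries the same kind of change on the core of compound 3, (methoxy in place of fluoro on an aromatic carbon); here the place is ortho to a large group, whereas in compound 2 it is meta to a large group. For compound 4 a step of similar size is expected, a 3.0-fold higher number from compound 3 to compound 4 (0.48 log units; beyond the scatter), resting on an at least 2.7-fold higher number from compound 1 to compound 2 (0.44 log units; beyond the scatter). Compound 4 is estimated at 18000 nM in this assay, with a range from 7000 nM to 45000 nM.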

Compound 4, half-maximal inhibitory concentration: > 25000 nM
Compound 4: a limit, no number; the forecaster's own chance of this, stated with the estimate: 35%; middle value at least 1.3-fold (0.14 log units) from the limit.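

In this assay, methoxy in place of fluoro moves the number the same way on both cores, with an at least 4.1-fold higher number from compound 3 to compound 4 (0.61 log units; beyond the scatter), and the two steps set side by side read: the same change on two cores in this assay, an at least 2.7-fold higher number (0.44 log units; beyond the scatter) from compound 1 to compound 2 and an at least 4.1-fold higher number (0.61 log units; beyond the scatter) from compound 3 to compound 4; the limit leaves it open whether they differ

Compound 4 stands at a limit, > 25000 nM, not at a number. The series also shows an at least 2.7-fold higher number from compound 1 to compound 4 (0.44 log units; beyond the scatter), while the steps between the two limits cannot be read, so the direction of the change carries across these two cores, but its size on either core does not.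

On these data alone, the true size of the methoxy step on each core stays open. Also open, as far as these compounds go, is whether a hydroxyl, an amine or a nitrile on that aromatic carbon would track with fluoro or with methoxy.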